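This account rests on a few compounds, and the source may have more. Where it says the series, first, only, none or still open, it means among the compounds named here.

Of the compounds shown here, three built on one shared core have been tested in a functional assay on Ehrlich cells (Mus musculus) for cytotoxicity, tested at 10 ug/mL; a higher number here means a stronger effect of the compound at the concentration tested, a lower number a weaker effect. Compound 1 `COc1cc(N2C(N)=C(C#N)C(/C=C/c3ccccc3)C3=C2CC(C)(C)CC3=O)cc(OC)c1OC` gives 10%. Compound 2 `COc1cc(N2C(N)=C(C#N)C(c3c(O)ccc4ccccc34)C3=C2CC(C)(C)CC3=O)cc(OC)c1OC` gives 2%. Compound 3 `COc1cc(N2C(N)=C(C#N)C(c3ccccc3Cl)C3=C2CC(C)(C)CC3=O)cc(OC)c1OC` gives 10%. Among these three numbers compound 2 holds the lowest, yet the two steps that lead away from it, a number 8 percentage points lower from compound 1 to compound 2 (within the scatter) and a number 8 percentage points higher from compound 2 to compound 3 (within the scatter), both lie inside the usual scatter of repeated measurements, so the three compounds cannot truly be told apart on this assay.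

Compound 4 `COc1cc(N2C(N)=C(C#N)C(c3ccc(O)cc3)C3=C2CC(C)(C)CC3=O)cc(OC)c1OC` is the next compound, not yet measured. It differs from compound 2 in a single place: 4-hydroxyphenyl in place of 2-hydroxynaphthalen-1-yl on a saturated ring carbon. For the measured compounds named here, the same saturated ring carbon is the only place that changes in each of the three measured steps, a number 8 percentage points lower from compound 1 to compound 2 (within the scatter), no change at the digits printed from compound 1 to compound 3 (within the scatter) and a number 8 percentage points higher from compound 2 to compound 3 (within the scatter), and none of them moves the read-out beyond the scatter. Whether the group on that carbon is a 2-phenylethenyl, a 2-chlorophenyl or a 2-hydroxynaphthalen-1-yl, the activity stays low and flat. A 4-hydroxyphenyl is therefore expected to behave in the same way, giving a step of a number 4 percentage points higher from compound 2 to compound 4 (within the scatter) that stays within the scatter. The estimate for compound 4 in this assay is 6%, with a range from 0% to 16%.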

Compound 4, a percentage reported as activity, at one concentration (the size of the read-out at that concentration, not a potency): 10%
For compound 4 the middle estimate is 4 percentage points below the measured one; measured number inside the range.
By their numbers in this assay, from the lowest: compounds 2, 1, 3 and 4 (each within the scatter of the next).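

For the compounds shown here, the new result is the first to shrink the group on this saturated ring carbon while keeping a hydroxyl: in this assay, 4-hydroxyphenyl, with one six-membered aromatic ring and 7 heavy atoms, replaces 2-hydroxynaphthalen-1-yl, with two such rings and 11 heavy atoms, and the step stays within the scatter (a number 8 percentage points higher from compound 2 to compound 4 (within the scatter)). The two other comparisons also give no readable difference, with 4-hydroxyphenyl in place of 2-chlorophenyl (no change at the digits printed from compound 3 to compound 4 (within the scatter)) and in place of 2-phenylethenyl (no change at the digits printed from compound 1 to compound 4 (within the scatter)), so all four groups at this position remain indistinguishable in this test. No supporting measurement is available to explain this similarity.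

The compounds shown leave open whether a group of a different kind on this carbon, such as an amine, a carboxylic acid or a longer alkyl chain, would move the read-out beyond the scatter. They also leave open what would happen if the 3,4,5-trimethoxyphenyl group or the cyano group were exchanged, since every comparison here changes only the saturated ring carbon.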